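The source may report more compounds than this note shows. Statements on the series, on what has been measured and on what is new or still open speak of the compounds shown alone.

Measured in a functional assay on CHO-K1 cells for antagonist activity at melanin-concentrating hormone receptor 1 (Homo sapiens), read by inositol phosphate accumulation; a higher number here means a weaker inhibitor, a lower number a stronger inhibitor:
compound 1 `Cc1nc(N2CCC(O)CC2)nc2ccc(NC(=O)C(C)(C)Oc3ccc(Cl)cc3)cc12` gives only a limit of the assay, > 10000 nM.
compound 2 `CCC1(O)CCN(c2nc(C)c3cc(NC(=O)COc4ccc(Cl)cc4)ccc3n2)CC1` gives 384 nM.
compound 3 `Cc1nc(N2CCC(O)(C3CC3)CC2)nc2ccc(NC(=O)COc3ccc(OC(F)(F)F)cc3)cc12` gives 33 nM.

Compound 2 carries the highest of the two numbers in this assay; compound 3 sits well below it, beyond the scatter of repeats. Compound 1 stands at the limit (the limit of > 10000 nM in this assay, at which 1 of the 3 values shown sits).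

The next step is compound 4 `Cc1nc(N2CCN(C3CCCC3)CC2)nc2ccc(NC(=O)COc3ccc(Cl)cc3)cc12`, which differs from compound 2 in one place: 4-cyclopentylpiperazin-1-yl in place of 4-ethyl-4-hydroxypiperidin-1-yl on an aromatic carbon. For the measured compounds named here, no measured pair shows this kind of change, so no step size can be read off. The expectation is a step toward a lower number, a 1.9-fold lower number from compound 2 to compound 4 (0.28 log units; within the scatter), though it may stay within the scatter. Compound 4 is estimated at 200 nM in this assay, with a range of 60 nM to 800 nM.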

Compound 4, half-maximal inhibitory concentration: 150 nM
Compound 4: the middle estimate sits 1.3-fold (0.12 log units) above what was measured; low and high end bracket the measured number.
By their numbers in this assay, from the lowest: compound 3; then compound 4; then compound 2. At a limit, above all of these: compound 1.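

For the compounds shown here, compound 4 gives the only step read at this carbon between two ring nitrogen atoms: in this assay, 4-cyclopentylpiperazin-1-yl in place of 4-ethyl-4-hydroxypiperidin-1-yl lowers the number (a 2.6-fold lower number from compound 2 to compound 4 (0.41 log units; beyond the scatter)). The position therefore accepts a group with 0 hydrogen-bond donors and a second ring, so the hydroxyl of compound 2 is not needed to reach this range. Nothing measured here accounts for the step.

Going by these compounds, whether the cyclopentyl ring or the piperazine ring drives the change remains open. A 4-methylpiperazin-1-yl group or an open-chain amine such as dimethylamino at this carbon would separate the two.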